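From compound 1 to compound 4: adding a benzyloxy group

The compounds below may be only part of what the source reports. "The series", "measured", "known", "first", "only" and "open" are said of these compounds alone.

In an ADME assay on BHK-21 cells (Mesocricetus auratus) for cytotoxicity, read by MTT assay, with a stated time of 72 h (on this read-out higher numbers stand for lower toxicity in this test and lower numbers for higher toxicity in this test), compound 1 (`NS(=O)(=O)c1ccc(N2N=C(c3ccccc3)CC2c2ccccc2F)cc1`) gives 21000 nM. Compound 2 (`NS(=O)(=O)c1ccc(N2N=C(c3ccccc3)CC2c2ccccc2Cl)cc1`) gives 13000 nM, and that gap is no larger than repeat measurements would produce. Compound 3 (`Cc1ccc(C2CC(c3ccc(Oc4ccccc4)cc3)=NN2c2ccc(S(N)(=O)=O)cc2)cc1`) gives 8000 nM, a clearly lower number than that of compound 1, so compound 1 stands at the less toxic end of this small set.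

Compound 4 (`NS(=O)(=O)c1ccc(N2N=C(c3ccc(OCc4ccccc4)cc3)CC2c2ccccc2F)cc1`) keeps the core of compound 1 and carries one change, benzyloxy in place of hydrogen on an aromatic carbon, para to a large group.

Among the measured compounds shown here, only one measured step links two compounds that differ in a single place: a 1.6-fold lower number from compound 1 to compound 2 (0.21 log units; within the scatter). That swap is small and of another kind, so it says little about adding a large group. The nearest guide is compound 3 at 8000 nM, which also bears a large oxygen-linked aromatic group, although it differs from compound 1 in more than one place. A modest move towards higher toxicity in this assay therefore seems likely, and the expected step is a 2.1-fold lower number from compound 1 to compound 4 (0.32 log units; beyond the scatter). For compound 4 the estimated value is 10000 nM, with an expected range from 4500 nM to 25000 nM.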

Compound 4, half-maximal cytotoxic concentration: 90000 nM
For compound 4 the middle estimate is 9.0-fold (0.95 log units) below the measured one; the measured number lies above the stated range.
By their numbers in this assay, from the lowest: compounds 3, 2 and 1 (each within the scatter of the next, the first and the last beyond it); then compound 4.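

In this assay, among the compounds shown here, the only earlier step between compounds differing in one place was a small swap on an aromatic carbon, a 1.6-fold lower number from compound 1 to compound 2 (0.21 log units; within the scatter), and it said nothing about this position. For the compounds shown here, the new step, a 4.3-fold higher number from compound 1 to compound 4 (0.63 log units; beyond the scatter), is the first reading for a change here, and it shows that benzyloxy in place of hydrogen, para to a large group, goes with lower toxicity in this test, not higher, and by more than repeat measurements would produce. Nothing available here gives a measured reason for this rise, so the step stands as an observation only.

The compounds shown leave open which part of the benzyloxy group goes with the higher number: the oxygen link, the added ring or simply the size of the whole group, and a methoxy group, a hydroxyl group or a longer phenylpropoxy chain at the same place would separate these. They also leave open whether the same change gives a step of like size when chloro replaces fluoro, as it does in compound 2.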